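A few compounds are considered here, and "the series" means these few. Any claim that something is new, unique, unknown or untested is made for them only; others in the source may bear on it.

Working notes on a series built on one shared core. Compound 1 `O=C(CSc1nc(Nc2ccccc2)c2ccccc2n1)Nc1ccccc1F` gives 9350 nM in a functional assay on NCI-H1975 cells (Homo sapiens) for inhibition, read by MTT assay, with a stated time of 72 h; on this read-out lower numbers stand for stronger inhibition and higher numbers for weaker inhibition. Compound 2 `O=C(CSc1nc(Nc2ccccc2)c2ccccc2n1)Nc1cccc(Br)c1` gives 10100 nM in this assay; its number is one of only two so far, and the step of a 1.1-fold higher number from compound 1 to compound 2 (0.03 log units; within the scatter) lies within the scatter, so compound 2 and compound 1 are not distinguished by this read-out. Compound 3 `O=C(CSc1nc(Nc2ccccc2)c2ccccc2n1)Nc1ccc(Cl)cc1` awaits measurement in this assay. It differs from compound 2 as follows: 4-chlorophenyl in place of 3-bromophenyl on an amide-type nitrogen. Within the data shown here, the single step that bears on this change is the earlier exchange of one aryl group on the same amide-type nitrogen, a 1.1-fold higher number from compound 1 to compound 2 (0.03 log units; within the scatter), which stayed within the scatter. On that basis no step beyond the scatter is expected for compound 3 in this assay, the estimated step being a 1.0-fold lower number from compound 2 to compound 3 (0.00 log units; within the scatter). The estimate for compound 3 in this assay is 10000 nM, with an expected range from 4000 nM to 25000 nM.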

Compound 3, half-maximal inhibitory concentration: 8040 nM
For compound 3 the middle estimate is 1.2-fold (0.09 log units) above the measured one; low and high end bracket the measured number.
By their numbers in this assay, from the lowest: compounds 3, 1 and 2 (each within the scatter of the next).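

In this assay the amide-type nitrogen now carries three different halogen-bearing phenyl groups, and the read-out does not separate them: a 1.3-fold lower number from compound 2 to compound 3 (0.10 log units; within the scatter) and a 1.2-fold lower number from compound 1 to compound 3 (0.07 log units; within the scatter) both lie within the scatter. Where one exchange stood before, 2-fluorophenyl, 3-bromophenyl and 4-chlorophenyl now form a set of three that are not distinguished at this place, with chlorine joining fluorine and bromine as the halogen on the ring. No measurement bearing on this result is available to explain it.

The compounds shown carry only halogen-bearing phenyl groups on this nitrogen, so it stays open whether a phenyl group with a carboxylic acid or an amine, or a longer chain in place of the phenyl group, would give a step beyond the scatter. Any change away from this nitrogen, on the shared core, also stays open.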